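A few compounds are considered here, and "the series" means these few. Any claim that something is new, unique, unknown or untested is made for them only; others in the source may bear on it.

Compound 1 `CCc1ccc(NS(=O)(=O)c2ccc(N3CCNC3=O)cc2)cc1` gives 660 nM
Compound 2 `CCCCOc1ccc(NS(=O)(=O)c2ccc(N3CCNC3=O)cc2)cc1` gives 630 nM

Both values come from a functional assay on HT-29 cells (Homo sapiens) for antiproliferative activity, read by sulforhodamine B assay, with a stated time of 48 h; a lower number here means a stronger inhibitor, a higher number a weaker inhibitor. In this assay, among the compounds with values here, compound 2, at 630 nM, stands level with compound 1, its only neighbour, and the two cannot be told apart. The next compound, compound 3 `O=C1NCCN1c1ccc(S(=O)(=O)Nc2ccc(Br)cc2)cc1`, differs from compound 2 by bromo in place of butoxy on an aromatic carbon, so bromo takes the place of butoxy. Within the data shown here, one measured step bears on this, the exchange of ethyl for butoxy on an aromatic carbon, which gave a 1.0-fold lower number from compound 1 to compound 2 (0.02 log units; within the scatter). Among the measured compounds shown here, no measured compound carries bromo, so this evidence is indirect. For the measured compounds named here, with only that step as a guide, no change beyond the scatter is expected, and the expected step is a 1.1-fold higher number from compound 2 to compound 3 (0.05 log units; within the scatter) in this assay. The estimate for compound 3 is 700 nM, with 250 nM to 2000 nM as its expected range.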

Compound 3, half-maximal inhibitory concentration: 300 nM
For compound 3 the middle estimate is 2.3-fold (0.37 log units) above the measured one; measured number inside the range.
By their numbers in this assay, from the lowest: compound 3; then compounds 2 and 1 (each within the scatter of the next).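

Compound 1 and compound 2 had left this aromatic carbon looking insensitive to the exchange of ethyl for butoxy, but bromo shows that the position can respond in this assay. Bromo in place of butoxy gives a 2.1-fold lower number from compound 2 to compound 3 (0.32 log units; beyond the scatter), and bromo in place of ethyl gives a 2.2-fold lower number from compound 1 to compound 3 (0.34 log units; beyond the scatter), so both changes run in the same direction and are modest in size. Nothing available explains why bromo differs here from the two other groups.

The compounds shown leave open whether this shift is particular to bromo or would also appear with chloro or iodo, and how an amine or a carboxylic acid on the same carbon would read. They also leave open whether bromo would give a similar step if another part of the shared core were changed.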